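Oxetanyl replacement on the side chain of compound 3

The source may hold more compounds than are shown below. What is called first, only, known or untested is meant among the compounds shown, and "the series" means these compounds.

Compound 1 `CC(C)(O)CCn1c(Cn2nc(S(C)(=O)=O)c3ccncc32)nc2cc(Cl)ccc21` in an ADME assay on HEp-2 cells (Homo sapiens) for cytotoxicity, with a stated time of 4 days (a lower number here means that less compound is tolerated, a higher number that more compound is tolerated), gives > 100000 nM, a limit of the assay.
Compound 2 `CC(C)(O)CCCn1c(Cn2nc(S(C)(=O)=O)c3ccncc32)nc2cc(Cl)ccc21` in this assay gives > 100000 nM, a limit of the assay.
Compound 3 `CS(=O)(=O)c1nn(Cc2nc3cc(Cl)ccc3n2CCC(O)C(F)F)c2cnccc12` in this assay gives > 100000 nM, a limit of the assay.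

Compound 3 stands where every measured member of the series stands: at the limit of > 100000 nM in this assay, at which 3 of the 3 values shown sit. Within the data shown here, no compound has a read number, so the steps among the measured compounds carry no size: a step that the two limits leave unreadable from compound 1 to compound 2, a step that the two limits leave unreadable from compound 1 to compound 3 and a step that the two limits leave unreadable from compound 2 to compound 3 are all unreadable, and the three chain variants on the aromatic nitrogen of the shared core cannot be ranked against each other.

Compound 4 `CS(=O)(=O)c1nn(Cc2nc3cc(Cl)ccc3n2CC2COC2)c2cnccc12` differs from compound 3 by oxetan-3-yl in place of 3,3-difluoro-2-hydroxypropyl on a saturated chain carbon bound to an aromatic nitrogen. Among the measured compounds shown here, none of the measured steps gives a readable size for a change on this chain; the only information is that three differing chains all sit at the limit. The step is therefore expected to be a step that the limit leaves unreadable from compound 3 to compound 4, with compound 4 most likely again reported as a limit. The estimate for compound 4 in this assay is 150000 nM, in the range 40000 nM to 400000 nM.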

Compound 4, half-maximal cytotoxic concentration: > 100000 nM
Compound 4 gave a limit, no number; the forecaster's own chance of this, stated with the estimate: 80%; the middle value does not contradict the limit.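

Compound 4 gives a limit in this assay, so its steps to compounds 1, 2 and 3 cannot be read: the limit of > 100000 nM in this assay, at which 4 of the 4 values shown sit.

The compounds shown leave open whether these chains on the shared core differ at all in the concentration tolerated.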